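The source may report more compounds than this note shows. Statements on the series, on what has been measured and on what is new or still open speak of the compounds shown alone.

Series notes. Compound 1 `Cc1nc(C2CC2)cc2nn(-c3ccccc3)cc12` and compound 2 `Cc1nc(-c2ccccc2)cc2nn(-c3ccccc3)cc12` share one core and differ on an aromatic carbon. In a functional assay on K562 cells (Homo sapiens) for inhibition, read by fluorescence, with a stated time of 72 h (on this read-out lower numbers stand for stronger inhibition of growth and higher numbers for weaker inhibition of growth), compound 1 gives 25900 nM, and compound 2 gives 6300 nM. Among the compounds with values here, the only measured step, a 4.1-fold lower number from compound 1 to compound 2 (0.61 log units; beyond the scatter), sets compound 2 at the lowest of the two numbers seen so far, with compound 1 the nearest neighbour.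

Compound 3 `Cc1nc(-c2ccsc2)cc2nn(-c3ccccc3)cc12` remains to be measured in this assay. Its change from compound 2, (thiophen-3-yl in place of phenyl on an aromatic carbon), swaps one aromatic ring for another at the same aromatic carbon. Within the data shown here, no measured step covers an exchange of this kind; the step from compound 1 to compound 2 concerns a ring replacing a non-aromatic group and bears on it only loosely. The expectation is therefore a step near or within the scatter, leaning slightly toward a lower number, as a 1.3-fold lower number from compound 2 to compound 3 (0.10 log units; within the scatter). Compound 3 is estimated at 5000 nM, within a range of 2000 nM to 14000 nM.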

Compound 3, concentration for 50% growth inhibition: 10000 nM
Beside the measured number, compound 3's estimate is 2.0-fold (0.30 log units) below it; low and high end bracket the measured number.
By their numbers in this assay, from the lowest: compounds 2 and 3 (each within the scatter of the next); then compound 1.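

In this assay, thiophen-3-yl in place of phenyl on this aromatic carbon gives (a 1.6-fold higher number from compound 2 to compound 3 (0.20 log units; within the scatter)), so at this position a five-membered aromatic ring with a sulfur atom cannot be told apart from the six-membered carbon ring. Thiophen-3-yl in place of cyclopropyl gives (a 2.6-fold lower number from compound 1 to compound 3 (0.41 log units; beyond the scatter)), so the advantage over cyclopropyl is no longer seen with phenyl alone but with two different aromatic rings. Nothing available explains these numbers.

Still open, going by these compounds, is how a pyridyl ring, a substituted phenyl, an amine or a carboxylic acid on this carbon would read out. The compounds shown also vary this one carbon only, so the contribution of the methyl group and of the other phenyl group on the shared core remains unknown.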